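The compounds below may be only part of what the source reports. "The series", "measured", "known", "first", "only" and "open" are said of these compounds alone.

Measured so far:
compound 1 `O=C(NCc1ccccc1)c1ccccc1OCc1ccccc1` gives 34200 nM in an assay on lysate for inhibition of phosphatidylcholine:ceramide cholinephosphotransferase 2 (Homo sapiens), read by HPLC, with stated times of 30 min and 2 h; a lower number here means a stronger inhibitor, a higher number a weaker inhibitor
compound 2 `O=C(Nc1cccnc1)c1ccccc1OCc1ccccc1Cl` gives 1100 nM in this assay

Compound 2 holds the lowest of the two numbers; its nearest neighbour, compound 1, sits far higher, well beyond the usual scatter. Compound 3 `O=C(Nc1cccnc1)c1ccccc1OCc1c(F)cccc1Cl` is the next compound, not yet measured. It differs from compound 2 in one place: fluoro in place of hydrogen on an aromatic carbon. A single fluoro entering at an aromatic carbon is a small change, so the step in this assay is expected to stay within the scatter, with no clear direction. On that basis, compound 3 is estimated at 900 nM, between 300 nM and 3000 nM, an expected step of a 1.2-fold lower number from compound 2 to compound 3 (0.09 log units; within the scatter).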

Compound 3, half-maximal inhibitory concentration: 1500 nM
Compound 3: the middle estimate sits 1.7-fold (0.22 log units) below what was measured; the range from low to high includes it.
By their numbers in this assay, from the lowest: compounds 2 and 3 (each within the scatter of the next); then compound 1.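

Putting a fluoro on this aromatic carbon, ortho to a large group, turns 2-chlorophenyl into 2-chloro-6-fluorophenyl and gives a 1.4-fold higher number from compound 2 to compound 3 (0.13 log units; within the scatter) in this assay. So this position accepts a fluoro, and compound 2 and compound 3 cannot be told apart in this measurement. Nothing measured here gives a reason for this result.

Fluoro is a single atom, so these compounds leave open whether a larger group on the same carbon, such as methoxy or an amine, would be tolerated as well.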